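The source may hold more compounds than are shown below. What is called first, only, known or untested is meant among the compounds shown, and "the series" means these compounds.

The measured compounds are compound 1 `CCOC(=O)C(=O)Nc1nc(-c2ccc(O)cc2)cs1` and compound 3 `CCOC(=O)C(=O)Nc1nc(-c2cc(OC)cc(OC)c2)cs1`, each with a number, and compound 2 `O=C(O)C(=O)Nc1nc(-c2ccc(O)cc2)cs1`, for which only a limit was reported.

In a functional assay on the whole organism with Rattus norvegicus as the target (a lower number here means that less compound is needed, a higher number that more compound is needed for the effect), compound 1 gives about 15 mg/kg. Compound 3 gives about 10 mg/kg, which puts it nearest compound 1, within the scatter of that number. Compound 2 gives > 3 mg/kg, a limit of the assay and not a number (the limit of > 3 mg/kg in this assay, at which 1 of the 3 values shown sits). The change from compound 1 to compound 2 is hydrogen in place of ethyl on an oxygen next to a carbonyl group, and its step is a step that the limit leaves unreadable from compound 1 to compound 2. The difference between the cores of compound 1 and compound 3 is not broken down here.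

Compound 4 `COc1cc(OC)cc(-c2csc(NC(=O)C(=O)O)n2)c1` has not yet been measured; it differs from compound 3 by hydrogen in place of ethyl on an oxygen next to a carbonyl group, the same change as from compound 1 to compound 2. The step from compound 1 to compound 2 has no readable size a step that the limit leaves unreadable from compound 1 to compound 2, so the expectation for compound 4 rests on compound 3 alone, with a wide range. For compound 4 the expected step is no change at the digits printed from compound 3 to compound 4 (within the scatter). Compound 4 is estimated at 10 mg/kg, with a range from 3 mg/kg to 40 mg/kg.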

Compound 4, dose for half-maximal effect: about 1 mg/kg
Compound 4: middle estimate off by 10-fold (1.00 log units), on the high side, outside the stated range (below it).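

In this assay, hydrogen in place of ethyl on an oxygen next to a carbonyl group gives a 10-fold lower number from compound 3 to compound 4 (1.00 log units; beyond the scatter) on the core of compound 3. The same change on the core of compound 1 cannot be read, because compound 2 sits at a limit of the assay and not at a number: the limit of > 3 mg/kg in this assay, at which 1 of the 4 values shown sits.

The size of this change is therefore known on one core only, and the compounds do not show whether it carries over to the other core.

The compounds shown leave open how the number would move with methyl or a longer chain in place of ethyl. They also leave open what an amine in place of the hydroxy of the carboxy group would give on either core.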